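From oxan-4-yl to pyrimidin-4-yl on compound 2

The compounds below may be only part of what the source reports. "The series", "measured", "known", "first", "only" and "open" are said of these compounds alone.

In a physicochemical assay for lipophilicity (a higher number here means a more lipophilic compound, a lower number a more polar compound), the measured compounds read:
compound 1 `CC(C)(C)C#Cc1cc(N(C(=O)[C@H]2CC[C@H](C)CC2)[C@H]2CC[C@](O)(CO[C@H]3CCOC3)CC2)c(C(=O)O)s1` gives 2.4
compound 2 `CC(C)(C)C#Cc1cc(N(C(=O)[C@H]2CC[C@H](C)CC2)[C@H]2CC[C@H](OC3CCOCC3)CC2)c(C(=O)O)s1` gives 2.4
compound 3 `C[C@@H]1CC[C@@H](C(=O)N(c2cc(C#CC(C)(C)C)sc2C(=O)O)[C@H]2CC[C@H](OC3CCOC3)CC2)[C@@H](O)C1` gives 2.2

Compound 2 at 2.4 stands level with compound 1 and within the usual scatter of compound 3, so these three values cannot be put in any order.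

Compound 4 `CC(C)(C)C#Cc1cc(N(C(=O)[C@H]2CC[C@H](C)CC2)[C@H]2CC[C@H](Oc3ccncn3)CC2)c(C(=O)O)s1` departs from compound 2 in one place: pyrimidin-4-yl in place of oxan-4-yl on an oxygen on a saturated carbon in short, pyrimidin-4-yl in place of oxan-4-yl on an oxygen on a saturated carbon. It has not yet been measured.

For the measured compounds named here, no two measured compounds differ in just one place, so no direct step is available as a guide. Going by the values given here, the only evidence is the narrow spread of the values: compound 3 at 2.2 and compound 1 at 2.4 lie within the scatter of each other even though their structures differ. On that thin basis, the change expected in this assay is a slight rise that stays within the scatter, estimated as a number 0.10 log units higher from compound 2 to compound 4 (within the scatter) and no more.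

For compound 4 the estimate is 2.5 with an expected range of 2.1 to 2.9 in the same measurement.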

Compound 4, distribution coefficient: 2.3
Estimate against measurement, compound 4: 0.20 log units above; the range from low to high includes it.
By their numbers in this assay, from the lowest: compounds 3, 4, 1 and 2 (each within the scatter of the next).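

Compound 2 and compound 4 differ in one place only. For the compounds shown here, they give the first direct step in this set. In this assay, putting pyrimidin-4-yl in place of oxan-4-yl on an oxygen on a saturated carbon gives a number 0.10 log units lower from compound 2 to compound 4 (within the scatter), so this reading does not separate the two compounds, even though the change is a large one on paper: a six-membered non-aromatic ring with 1 hetero atom gives way to a six-membered aromatic ring with 2 hetero atoms, and the count of hydrogen-bond acceptors goes from 1 to 2, while the count of heavy atoms stays equal. Nothing available here accounts for this result, so the step stands as an observation without an explanation.

This single step says nothing about how a group of a different kind would read at this position, such as an amine like piperidin-4-yl or a carboxylic acid on the same oxygen. It also leaves open whether the swap from oxan-4-yl to pyrimidin-4-yl would read the same on a compound that differs elsewhere, such as one with the extra hydroxyl of compound 1.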